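From bromo to hydroxy in an antiproliferative series

The source may hold more compounds than are shown below. What is called first, only, known or untested is meant among the compounds shown, and "the series" means these compounds.

- compound 1 `COc1ccc(C(=O)c2ccc(OC)c3c2OC(C)(C)C=C3)c(NC(=O)CBr)c1`: 2140 nM
- compound 2 `COc1ccc(C(=O)c2ccc(OC)c3c2C=CC(C)(C)O3)c(NC(=O)CBr)c1`: 3680 nM

In a functional assay on HeLa cells (Homo sapiens) for antiproliferative activity, read by MTT assay, with a stated time of 48 h (a higher number here means a weaker inhibitor, a lower number a stronger inhibitor), compound 1 gives 2140 nM and compound 2 gives 3680 nM. These two values lie within the usual scatter of each other, so neither compound stands apart. Compound 3 `COc1ccc(C(=O)c2ccc(OC)c3c2OC(C)(C)C=C3)c(NC(=O)CO)c1` keeps the core of compound 1 but has hydroxy in place of bromo on a saturated chain carbon bound to a carbonyl carbon. Going by the values given here, no measured pair shows this change, so the expectation is a judgment. A weaker result in this assay is expected, beyond the scatter, with an estimated 3.3-fold higher number from compound 1 to compound 3 (0.51 log units; beyond the scatter). Compound 3 is expected at 7000 nM, within an estimated range of 1800 nM to 30000 nM.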

Compound 3, half-maximal inhibitory concentration: 100 nM
Beside the measured number, compound 3's estimate is 70-fold (1.85 log units) above it; measured number outside the range, below it.
By their numbers in this assay, from the lowest: compound 3; then compounds 1 and 2 (each within the scatter of the next).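

On a saturated chain carbon bound to a carbonyl carbon, the group carried matters greatly in this assay: hydroxy in place of bromo gives a 21-fold lower number from compound 1 to compound 3 (1.33 log units; beyond the scatter) and marks this position as highly sensitive to change, something compound 1 and compound 2, which both carry bromo, could not show. The swap replaces one heavy atom with another and adds one hydrogen-bond donor and one hydrogen-bond acceptor, yet nothing available explains the size of the step. On these data alone, whether an amine or a methoxy group on that carbon would match hydroxy remains open. So does whether hydroxy would bring a similar step to the core of compound 2.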